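Dimethoxyquinolone amides: antiproliferative status and next step

This account rests on a few compounds, and the source may have more. Where it says the series, first, only, none or still open, it means among the compounds named here.

Compound 1 `COc1ccc(-c2cc(=O)c3c(OC)cc(OC)cc3n2Cc2ccccc2)cc1`, compound 2 `COc1ccc(-c2cc(=O)c3c(OC)cc(OC)cc3n2S(=O)(=O)c2ccc(C)cc2)cc1`, compound 3 `COc1cc(OC)c2c(=O)cc(C(=O)Nc3ccc(N4CCN(C)CC4)cc3)[nH]c2c1` and the not yet measured compound 4 `COc1cc(OC)c2c(=O)cc(C(=O)Nc3ccc(Oc4cccnc4)cc3)[nH]c2c1` share one core. In a functional assay on UoC-B1 cells (Homo sapiens) for antiproliferative activity, with a stated time of 72 h (a lower number here means that less compound is needed, a higher number that more compound is needed for the effect), compound 1 gives only a limit of > 17300 nM. For compound 2 the result in this assay is "not determined" (no result reported). Compound 3 also gives only a limit, > 19800 nM, in this assay. Among the three entries shown, compound 3 thus sits at the limit of > 19800 nM in this assay, at which 1 of the 3 values shown sits, one further entry is also a limit (the limit of > 17300 nM in this assay, at which 1 of the 3 values shown sits), and one carries no number. Among the compounds with values here, no step between measured compounds is available to size the change ((pyridin-3-yl)oxy in place of 4-methylpiperazin-1-yl on an aromatic carbon), (pyridin-3-yl)oxy in place of 4-methylpiperazin-1-yl on an aromatic carbon. Compound 4 is expected at 20000 nM (range 5000 nM to 60000 nM). The implied step that the limit leaves unreadable from compound 3 to compound 4 is expected to stay within the scatter, most likely again a limit.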

Compound 4, half-maximal effective concentration: 27700 nM
Compound 4: the middle estimate sits 1.4-fold (0.14 log units) below what was measured, and the stated range covers the measured number.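

Within the data shown here, compound 3 gives only a limit of > 19800 nM here, so no step to compound 4 can be read. The compounds shown leave open whether (pyridin-3-yl)oxy in place of 4-methylpiperazin-1-yl changes antiproliferative activity at all.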